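A Meta Substituent Swap on a Dienone Scaffold

The compounds below may be only part of what the source reports. "The series", "measured", "known", "first", "only" and "open" are said of these compounds alone.

Compound 1 `CC1=C(/C=C/C(=O)/C=C/c2ccccc2)C(C)(C)CCC1O` carries an unsubstituted phenyl ring on its dienone chain, and in a functional assay on PCa 2b cells (Homo sapiens) for cytotoxicity, read by MTT assay, with a stated time of 72 h (on this read-out higher numbers stand for weaker inhibition and lower numbers for stronger inhibition), compound 1 gives 12600 nM. Compound 2 `CC1=C(/C=C/C(=O)/C=C/c2ccccc2F)C(C)(C)CCC1O` places a fluoro on that ring, and in this assay compound 2 gives "not determined" (no result reported). Compound 3 `CC1=C(/C=C/C(=O)/C=C/c2cccc(F)c2)C(C)(C)CCC1O` holds its fluoro at a different position of the same ring, and in this assay compound 3 gives "not determined" (no result reported). Compound 3 therefore stands without a number of its own: only compound 1 supplies a measured figure among the three, and no comparison of compound 3 with any other compound can be drawn.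

Compound 4 `CC1=C(/C=C/C(=O)/C=C/c2cccc(C)c2)C(C)(C)CCC1O` differs from compound 3 by methyl in place of fluoro on an aromatic carbon. Among the compounds with values here, with no measured step between two compounds in this assay to guide the reading, the change is expected to bring no shift beyond the usual scatter, and compound 4 is expected to land near the figure of compound 1 in this assay, at about 12000 nM, within a range from 3000 nM to 45000 nM.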

Compound 4, half-maximal inhibitory concentration: 19000 nM
Compound 4: the middle estimate sits 1.6-fold (0.20 log units) below what was measured; the measured number falls inside the stated range.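

Within the data shown here, compound 4 gives the first readable step on this ring in this assay, and that step reads a 1.5-fold higher number from compound 1 to compound 4 (0.18 log units; within the scatter), so a methyl on an aromatic carbon, meta to a large group, stays within the scatter of the unsubstituted phenyl of compound 1. The change from 3-fluorophenyl to 3-methylphenyl itself cannot be read, since compound 3 has no number, and the measured answer at this position therefore concerns methyl against hydrogen only. Nothing given here offers an explanation for this result.

From the compounds shown here alone, whether an amine, a carboxylic acid or a longer chain at this same position would also stay within the scatter remains open. Also open, going by these compounds, is whether a methyl elsewhere on the ring would read the same way.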